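Extending the Acid Arm of Compound 2 by One Glycine

This account rests on a few compounds, and the source may have more. Where it says the series, first, only, none or still open, it means among the compounds named here.

Compound 2 `Cc1ccccc1NC(=O)N1C(=O)CC1CC(=O)O` is one of two close relatives, the other being compound 1 `Cc1ccccc1NC(=O)N1C(=O)C[C@H]1C(=O)NCCC(=O)O`. In an assay on K562 cells for agonist activity at integrin alpha-5/beta-1 (Homo sapiens), read by colorimetric assay, with stated times of 30 min and 1 h (a lower number here means that less compound is needed, a higher number that more compound is needed for the effect), compound 2 gives > 5000 nM, which is a limit of the assay rather than a number. Compound 1 likewise gives only a limit in this assay, namely > 5000 nM. So far, then, there is the limit of > 5000 nM in this assay, at which 2 of the 2 values shown sit, and neither compound shows a measurable effect. Compound 3 `Cc1ccccc1NC(=O)N1C(=O)CC1CC(=O)NCC(=O)O` has not been measured yet. It differs from compound 2 by (carboxymethyl)amino in place of hydroxy on a carbonyl carbon. Within the data shown here, no measured pair shows what such a change does, and the only evidence available is that both relatives sit at the limit. The step that the limit leaves unreadable from compound 2 to compound 3 is therefore expected to be none beyond the scatter, with compound 3 most likely staying at the limit as well. For compound 3 the estimated value in this assay is 8000 nM, with a range from 2000 nM to 40000 nM.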

Compound 3, half-maximal effective concentration: 9.9 nM
Beside the measured number, compound 3's estimate is 810-fold (2.91 log units) above it, outside the stated range (below it).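

The change on this carbonyl carbon, whose other neighbour is a saturated chain carbon, turns out to decide whether the compound registers at all in this assay: (carboxymethyl)amino in place of hydroxy gives an at least 500-fold lower number from compound 2 to compound 3 (2.70 log units; beyond the scatter). Among these compounds, compound 3 thus supplies the first real number, showing that the shared core can reach a low value once this arm is extended. The true size of the step stays a bound, since the starting point is only a limit: the limit of > 5000 nM in this assay, at which 2 of the 3 values shown sit.

Going by these compounds, what remains open is whether the gain rests on the amide hydrogen, on the terminal carboxylic acid, or on both, which a simple methyl amide or an ester at that end would separate. Also unsettled is how a longer chain between the amide and the acid would fare on this same core.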